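The source may report more compounds than this note shows. Statements on the series, on what has been measured and on what is new or still open speak of the compounds shown alone.

Of the compounds shown here, two have been measured in a functional assay on NCI-H226 cells (Homo sapiens) for inhibition, read by MTT assay, with a stated time of 48 h, tested at 10 uM; on this read-out higher numbers stand for more inhibition at the one concentration tested (going by the name of the read-out) and lower numbers for less inhibition. Compound 1 `COc1cc(NC(=O)Nc2cc(Nc3ccc(C)c(C)c3)ncn2)cc(OC)c1` gives 45.3% in this assay, the lower of the two numbers. Compound 2 `Cc1cc(F)cc(Nc2cc(NC(=O)Nc3c(Cl)cccc3Cl)ncn2)c1` gives 78.1% in this assay, a reading that lies beyond the usual scatter above compound 1. Compound 2 differs from compound 1 in more than one place, so the gap between them cannot be tied to any single change.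

Compound 3 `COc1cc(NC(=O)Nc2cc(Nc3cc(I)ccc3OC)ncn2)cc(OC)c1` has not yet been measured. It is built from compound 1 by one change: 5-iodo-2-methoxyphenyl in place of 3,4-dimethylphenyl on a nitrogen on an aromatic ring. Within the data shown here, no measured pair isolates what a change of this kind does to the inhibition reading. The step of a number 6.7 percentage points higher from compound 1 to compound 3 (within the scatter) is therefore expected to be small, within the usual scatter or only a little above it in the direction of more inhibition. Compound 3 is estimated at 52% in this assay, with a range from 28% to 76%, the width of that range reflecting how little the two measured compounds say about this particular change.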

Compound 3, a percentage reported as inhibition, at one concentration (the size of the read-out at that concentration, not a potency): 56.7%
Estimate against measurement, compound 3: 4.7 percentage points below; the measured number falls inside the stated range.
By their numbers in this assay, from the lowest: compound 1; then compound 3; then compound 2.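

In this assay, compound 1 and compound 3 form the only pair shown that differs in one place, so this is the first reading of what a change on this nitrogen can do. Putting 5-iodo-2-methoxyphenyl in place of 3,4-dimethylphenyl gives a number 11.4 percentage points higher from compound 1 to compound 3 (beyond the scatter), so the reading at this position responds to the groups on the ring and does not fall with this swap, although the step is modest. The change alters several things at once: both methyl groups leave, an iodine and a methoxy enter, and the count of hydrogen-bond acceptors on this group goes from none to one, and no measurement available here explains the rise.

From the compounds shown here alone, what remains open is which part of the swap carries the step, and a ring bearing only the iodine or only the methoxy would be needed to separate the two. Also open, going by these compounds, is how far this position stretches to quite different groups, such as a phenyl ring bearing an amine or a carboxylic acid, or a longer chain in place of the ring.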